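Methoxy for Trifluoromethyl on the Styryl Lactone Aryl Ring

The compounds below may be only part of what the source reports. "The series", "measured", "known", "first", "only" and "open" are said of these compounds alone.

Two compounds carry numbers in a functional assay on MCF7 cells (Homo sapiens) for inhibition, read by sulforhodamine B assay, with a stated time of 48 h; a lower number here means a stronger inhibitor of growth, a higher number a weaker inhibitor of growth. Compound 1 `COc1ccc(C2CC(=O)C=CO2)cc1` gives 173 uM in this assay, while compound 2 `O=C1C=CCC(/C=C/c2ccc(C(F)(F)F)cc2)O1` gives 51 uM, the lower of the two numbers and beyond the scatter from compound 1. Compound 3 `COc1ccc(/C=C/C2CC=CC(=O)O2)cc1` is not yet measured. It differs from compound 2 in one place: methoxy in place of trifluoromethyl on an aromatic carbon. Going by the values given here, no measured pair isolates this change, and compound 1 has a different core, so only a cautious guess is possible. A modest weakening of a 1.7-fold higher number from compound 2 to compound 3 (0.22 log units; within the scatter) is expected, and compound 3 is estimated at 85 uM, between 30 uM and 250 uM.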

Compound 3, concentration for growth inhibition (reported as GI): 25.5 uM
Beside the measured number, compound 3's estimate is 3.3-fold (0.52 log units) above it, and the stated range ends above it.
By their numbers in this assay, from the lowest: compounds 3 and 2 (each within the scatter of the next); then compound 1.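

On this aromatic carbon, para to a group of 9 heavy atoms, methoxy in place of trifluoromethyl gives in this assay a 2.0-fold lower number from compound 2 to compound 3 (0.30 log units; within the scatter). This first direct reading of the change shows that the two groups cannot be told apart at this position, although they differ in heavy atoms and hydrogen-bond acceptors. Nothing measured explains this outcome.

On these data alone, whether an amine or a carboxylic acid on this carbon would also stay within the scatter remains open. So does how the unsubstituted phenyl ring would read.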